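Benzylsulfonyl on the aromatic oxygen of compound 2

This account rests on a few compounds, and the source may have more. Where it says the series, first, only, none or still open, it means among the compounds named here.

In a functional assay on K562 cells (Homo sapiens) for cytotoxicity, read by MTT assay (a higher number here means a weaker inhibitor, a lower number a stronger inhibitor), compound 1 `COc1ccc(/C=C/C(=O)c2ccc(OC)c3c2OC(C)(C)C=C3)cc1OC(=O)CCl` gives 400 nM and compound 2 `COc1ccc(/C=C/C(=O)Oc2cc(/C=C/C(=O)c3ccc(OC)c4c3OC(C)(C)C=C4)ccc2OC)cc1` gives 380 nM, so compound 2 stands level with compound 1 within the scatter. Compound 3 `COc1ccc(/C=C/C(=O)c2ccc(OC)c3c2OC(C)(C)C=C3)cc1OS(=O)(=O)Cc1ccccc1` carries benzylsulfonyl in place of (2-(4-methoxyphenyl)ethenyl)carbonyl on an oxygen on an aromatic ring. Among the measured compounds shown here, the only measured step, a 1.1-fold lower number from compound 1 to compound 2 (0.02 log units; within the scatter), exchanged chloromethyl for 2-(4-methoxyphenyl)ethenyl on a carbonyl carbon and stayed within the scatter. For the measured compounds named here, no measured step replaces that carbonyl with a sulfonyl, so a shift beyond the scatter is not expected, though uncertainty remains wide. The expected change is a 1.2-fold higher number from compound 2 to compound 3 (0.07 log units; within the scatter). The estimated value for compound 3 is 450 nM, with an expected range from 150 nM to 1400 nM.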

Compound 3, half-maximal inhibitory concentration: > 10000 nM
Compound 3: only a limit was reported; the forecaster's own chance of this, stated with the estimate: 3%; middle value at least 22-fold (1.34 log units) away from the limit.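

Compounds 1 and 2 showed that the group on the carbonyl could change at this oxygen on an aromatic ring without moving the number beyond the scatter. Replacing the whole carbonyl-bearing group with benzylsulfonyl does not share that tolerance in this assay: an at least 26-fold higher number from compound 2 to compound 3 (1.42 log units; beyond the scatter), and an at least 25-fold higher number from compound 1 to compound 3 (1.39 log units; beyond the scatter). The reading for compound 3 is a limit, not a number: the limit of > 10000 nM in this assay, at which 1 of the 3 values shown sits.

The compounds shown do not separate the sulfonyl from the benzyl part of the new group. A methylsulfonyl or a phenylacetyl group on this oxygen would bear on that question.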